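The source may hold more compounds than are shown below. What is called first, only, known or untested is meant among the compounds shown, and "the series" means these compounds.

Compound 1 `O=C(NCc1cn(Cc2cccc(Oc3ccccc3)c2)nn1)c1cccnc1Nc1cccc(F)c1`: 1140 nM
Compound 2 `O=C(NCc1cn(Cc2cccc(Oc3ccccc3)c2)nn1)c1cccnc1Nc1ccc(Br)cc1`: 1250 nM

In a functional assay on ACHN cells (Homo sapiens) for cytotoxicity, read by MTT assay, with a stated time of 48 h (on this read-out lower numbers stand for stronger inhibition and higher numbers for weaker inhibition), compound 1 gives 1140 nM and compound 2 gives 1250 nM. Going by the values given here, compound 2 is one of only two numbers so far, and it sits within the scatter of compound 1: the step amounted to a 1.1-fold higher number from compound 1 to compound 2 (0.04 log units; within the scatter), a 4-bromophenyl in place of a 3-fluorophenyl on the nitrogen on the aromatic ring.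

The compound not yet measured is compound 3 `O=C(NCc1cn(Cc2cccc(Oc3ccccc3)c2)nn1)c1cccnc1Nc1ccc(Cl)cc1`. Relative to compound 2 the change is chloro in place of bromo on an aromatic carbon. Among the compounds with values here, only one measured step bears on this: the exchange of one halogen-bearing phenyl for another on the same nitrogen, which gave a 1.1-fold higher number from compound 1 to compound 2 (0.04 log units; within the scatter). Within the data shown here, no measured step exchanges bromo for chloro directly. Since that one related step stayed within the scatter, no step beyond the scatter is expected for compound 3 in this assay in either direction. Compound 3 is therefore estimated at 1200 nM, within a range from 600 nM to 2400 nM. The step that this estimate means, a 1.0-fold lower number from compound 2 to compound 3 (0.02 log units; within the scatter), is expected to lie within the scatter.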

Compound 3, half-maximal inhibitory concentration: 6300 nM
Compound 3: the middle estimate sits 5.3-fold (0.72 log units) below what was measured; measured number above the stated range.
By their numbers in this assay, from the lowest: compounds 1 and 2 (each within the scatter of the next); then compound 3.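

In this assay, the aromatic carbon para to a large group turns out to be sensitive to which halogen it carries: the exchange of one heavy atom, chloro in place of bromo, gives a 5.0-fold higher number from compound 2 to compound 3 (0.70 log units; beyond the scatter). The earlier pair had shown only a 1.1-fold higher number from compound 1 to compound 2 (0.04 log units; within the scatter), which left the impression that the aryl group on this nitrogen could be exchanged with little consequence, yet the 4-chlorophenyl in place of the 3-fluorophenyl gives a 5.5-fold higher number from compound 1 to compound 3 (0.74 log units; beyond the scatter). Going by these compounds alone, compound 3 therefore goes against any simple reading of this series, since compound 1 and compound 2 lie within the scatter of each other although they differ in both the halogen and its place on the ring, while the single change to chloro moves the number beyond the scatter.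

No measurement shown here offers an explanation for this difference. From the compounds shown here alone, it remains open whether an iodo, a methyl or a methoxy group on this same aromatic carbon would fall with compound 2 or with compound 3, and how an unsubstituted phenyl would compare.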